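This account rests on a few compounds, and the source may have more. Where it says the series, first, only, none or still open, it means among the compounds named here.

In a physicochemical assay for solubility, using the shake flask method, in simulated intestinal fluid, measured as kinetic solubility, with a stated time of 20 h, at pH 6.5 (on this read-out lower numbers stand for lower solubility and higher numbers for higher solubility), compound 1 `Fc1ccc(-c2nc3cnc(Nc4ccc(C(F)(F)F)cn4)cc3[nH]2)cc1F` gives >= 50000 nM, which is a limit of the assay and not an exact number. Compound 2 `Fc1ccc(Nc2cc3[nH]c(-c4ccc(F)c(F)c4)nc3cn2)nc1` gives >= 50000 nM in this assay, and this too is a limit. Among the compounds with values here, the one measured change, fluoro in place of trifluoromethyl on an aromatic carbon, is a step that the two limits leave unreadable from compound 1 to compound 2. All it offers is the limit of >= 50000 nM in this assay, at which 2 of the 2 values shown sit. Compound 3 `FC1(F)CC(c2nc3cnc(Nc4ccc(C(F)(F)F)cn4)cc3[nH]2)C1` differs from compound 1 by 3,3-difluorocyclobutyl in place of 3,4-difluorophenyl on an aromatic carbon. Within the data shown here, no measured step covers this exchange, so its size and direction cannot be read from the data. With only that shared limit to go on, no step beyond the scatter is expected in this assay. The estimated change is a number no higher from compound 1 to compound 3 (the limit leaves the size open). For compound 3 the expected value is 50000 nM, with an estimated range of 20000 nM to 100000 nM.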

Compound 3, solubility: 161000 nM
Compound 3: middle estimate off by 3.2-fold (0.51 log units), on the low side, outside the stated range (above it).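

In this assay, the step from compound 1 to compound 3 cannot be read, as the value for compound 1 is a limit and not an exact number. The compounds shown leave open both the size and the direction of the change when 3,3-difluorocyclobutyl takes the place of 3,4-difluorophenyl.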